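The source may report more compounds than this note shows. Statements on the series, on what has been measured and on what is new or still open speak of the compounds shown alone.

Compound 1 `CC1=C(C(=O)Nc2ccc(F)c(Cl)c2)C(c2cccc(Cl)c2)NC(=S)N1`: 10000 nM
Compound 2 `CC1=C(C(=O)Nc2ccc(F)c(Cl)c2)C(c2ccccc2Cl)NC(=S)N1`: 14800 nM

Both compounds were tested in a functional assay on SF-268 cells (Homo sapiens) for cytotoxicity, read by sulforhodamine B assay, with a stated time of 48 h; a lower number here means a stronger inhibitor of growth, a higher number a weaker inhibitor of growth. In this assay compound 1 gives 10000 nM, and compound 2 gives 14800 nM. Among the compounds with values here, the only difference between them is a 1.5-fold higher number from compound 1 to compound 2 (0.17 log units; within the scatter), so the two numbers cannot be told apart and compound 1 stands level with the one other compound measured.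

Compound 3 `CC1=C(C(=O)Nc2ccc(F)c(Cl)c2)C(c2cccc(Oc3ccccc3)c2)NC(=S)N1` is not yet measured. It differs from compound 1 in one place: phenoxy in place of chloro on an aromatic carbon. Within the data shown here, no measured step replaces a chloro group with a phenoxy group, and the one step that is known, from compound 1 to compound 2, moves the same chloro group around the ring and stays within the scatter. Among the measured compounds shown here, the expectation for compound 3 therefore rests only on how close the two known numbers lie, and no step beyond the scatter is expected in this assay, in either direction. Compound 3 is thus expected to give about 12000 nM, with a range from 4000 nM to 36000 nM, which corresponds to an expected step of a 1.2-fold higher number from compound 1 to compound 3 (0.08 log units; within the scatter).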

Compound 3, concentration for 50% growth inhibition: 8910 nM
Compound 3: the middle estimate sits 1.3-fold (0.13 log units) above what was measured, and the stated range covers the measured number.
By their numbers in this assay, from the lowest: compounds 3, 1 and 2 (each within the scatter of the next).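

In this assay, replacing the chloro group with phenoxy brings in far more atoms, seven heavy atoms against one, along with an extra aromatic ring and a hydrogen-bond acceptor, yet the result is a 1.1-fold lower number from compound 1 to compound 3 (0.05 log units; within the scatter). Within the data shown here, the earlier pair showed only that the chloro group could sit at a different place on the ring without a readable shift; this new pair shows that, on this aromatic carbon meta to a large group, a far bigger group also leaves the number indistinguishable from that of compound 1. No measurement offered here gives a reason for this lack of a readable difference.

As far as these compounds go, what remains open is whether a group of a different kind at this position, such as an amine or a carboxylic acid, would move the number in this assay beyond the scatter. From the compounds shown here alone, it is also open whether a change elsewhere on the shared core, such as a longer chain in place of the methyl group, would matter more than the changes on this ring have so far.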